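A Smaller Ring on the Amide Nitrogen of Compound 1

The source may hold more compounds than are shown below. What is called first, only, known or untested is meant among the compounds shown, and "the series" means these compounds.

Three compounds have been measured in an assay on HEK293 cells for positive allosteric modulation of metabotropic glutamate receptor 2 (Rattus norvegicus), read by thallium flux; on this read-out higher numbers stand for an effect only at larger amounts of compound and lower numbers for an effect already at smaller amounts:
compound 1 `O=C(O)c1cc(-c2cccc(COc3ccc4c(c3)CN(C3CCCCC3)C4=O)c2)ccc1Cl` gives 270 nM
compound 2 `CCCN1Cc2cc(OCc3cccc(-c4ccc(Cl)c(C(=O)O)c4)c3)ccc2C1=O` gives a limit of the assay, > 10000 nM
compound 3 `O=C(O)c1cc(-c2cccc(COc3ccc4c(c3)CN(CC3CC3)C4=O)c2)ccc1Cl` gives 80 nM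

Compound 1 has the highest of the two numbers; its nearest neighbour is compound 3, reached by a 3.4-fold lower number from compound 1 to compound 3 (0.53 log units; beyond the scatter). Compound 4 `O=C(O)c1cc(-c2cccc(COc3ccc4c(c3)CN(C3CC3)C4=O)c2)ccc1Cl` differs from compound 1 by cyclopropyl in place of cyclohexyl on an amide-type nitrogen in a ring. Among the measured compounds shown here, two steps bear on this: the modest one, a 3.4-fold lower number from compound 1 to compound 3 (0.53 log units; beyond the scatter), where a cyclopropyl ring is kept but set one carbon further out, and the large one, an at least 37-fold higher number from compound 1 to compound 2 (1.56 log units; beyond the scatter), which ends at the limit of > 10000 nM in this assay, at which 1 of the 3 values shown sits. A small ring set directly on the nitrogen sits between these cases, so a step in the unfavourable direction is expected, a 2.2-fold higher number from compound 1 to compound 4 (0.35 log units; beyond the scatter). Compound 4 is therefore estimated at 600 nM, with a range of 120 nM to 4000 nM.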

Compound 4, half-maximal effective concentration: 220 nM
Estimate against measurement, compound 4: 2.7-fold (0.44 log units) above; the range from low to high includes it.
By their numbers in this assay, from the lowest: compound 3; then compounds 4 and 1 (each within the scatter of the next). At a limit, above all of these: compound 2.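

In this assay, cyclopropyl and cyclohexyl on the amide-type nitrogen in a ring cannot be told apart, with a 1.2-fold lower number from compound 1 to compound 4 (0.09 log units; within the scatter), so ring size alone does not separate these two groups. Cyclopropylmethyl does stand apart from cyclopropyl at this position, with a 2.8-fold higher number from compound 3 to compound 4 (0.44 log units; beyond the scatter). The cyclopropyl of compound 4 also lies far from the open propyl chain, with an at least 45-fold lower number from compound 2 to compound 4 (1.65 log units; beyond the scatter), and this step starts from a limit of compound 2: the limit of > 10000 nM in this assay, at which 1 of the 4 values shown sits.

The compounds shown leave open how cyclobutyl or cyclopentyl on this nitrogen would read. They also leave open whether a branched chain such as isopropyl would follow the rings or propyl.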